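This account rests on a few compounds, and the source may have more. Where it says the series, first, only, none or still open, it means among the compounds named here.

Measured so far:
compound 1 `CCCCC#Cc1cc2cn([C@@H]3O[C@H](CO)[C@@H](O)[C@H]3O)c(=O)nc2o1`: > 144000 nM
compound 2 `CCCCC#Cc1cc2cn(C)c(=O)nc2o1`: >= 217000 nM
compound 3 `CCCCCCCCCCC#Cc1cc2cn([C@H]3C[C@H](O)[C@@H](CO)O3)c(=O)nc2o1`: 30000 nM

In a functional assay on HEL cells (Homo sapiens) for cytotoxicity (on this read-out lower numbers stand for higher toxicity in this test and higher numbers for lower toxicity in this test), compound 1 gives only a limit, > 144000 nM. Compound 2 likewise gives only a limit, >= 217000 nM. Among the compounds with values here, compound 3 is the one compound with an actual number, 30000 nM. Compound 4 `CCCCC#Cc1cc2cn([C@H]3C[C@H](O)[C@@H](CO)O3)c(=O)nc2o1` has not yet been tested. Compound 4 differs from compound 3 by hydrogen in place of hexyl on a saturated chain carbon, four bonds along the chain from a triple-bonded carbon. Compound 1 and compound 2, which also lack the hexyl, both sit at limits; compound 1 stands at the limit of > 144000 nM in this assay, at which 1 of the 3 values shown sits, and compound 2 stands at the limit of >= 217000 nM in this assay, at which 1 of the 3 values shown sits. Accordingly the step of a 5.0-fold higher number from compound 3 to compound 4 (0.70 log units; beyond the scatter) is expected to be large, toward lower toxicity, and most likely to end at a limit again. Compound 4 is therefore estimated at 150000 nM in this assay, within 40000 nM to 300000 nM.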

Compound 4, minimum cytotoxic concentration: > 150000 nM
Compound 4 was reported as a limit; the forecaster's own chance of this, stated with the estimate: 70%; the middle value sits exactly at the limit.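

In this assay, within the data shown here, hydrogen in place of hexyl on a saturated chain carbon, four bonds along the chain from a triple-bonded carbon, gives the one readable step at this position: an at least 5.0-fold higher number from compound 3 to compound 4 (0.69 log units; beyond the scatter). Compound 4 gives > 150000 nM, which is a limit. The steps from compound 1 and from compound 2 to compound 4 cannot be read.

Chains of intermediate length, such as propyl or ethyl in place of the hexyl's full extension, leave open how the number changes along the series. On these data alone, a chain ending in an amine or a carboxylic acid at this place also remains open.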